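Swapping Phenyl for Methylpyridinyl on a Saturated Ring Carbon

The source may report more compounds than this note shows. Statements on the series, on what has been measured and on what is new or still open speak of the compounds shown alone.

Three compounds have been examined in an assay on cells for agonist activity at D(4) dopamine receptor (Homo sapiens), read by luminescence and beta-arrestin recruitment, with a stated time of 90 min; on this read-out higher numbers stand for larger maximal responses and lower numbers for smaller maximal responses. Compound 1 `CCc1cccc(NC(=O)CN2CCN(c3ccc(Cl)cn3)CC2)c1` was reported as "not active" (no number reported), and compound 3 `Cc1cccc(NC(=O)CCN2CCC(c3ccccn3)CC2)c1` likewise came back as "not active" (no number reported). Compound 2 `Cc1cccc(NC(=O)CN2CCC(c3ccccc3)CC2)c1` is the only one of the three with a number: in this assay compound 2 reaches 14%, a small maximal response, and so it stands alone as the single quantified point in this set.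

Compound 4 `Cc1ccc(C2CCN(CC(=O)Nc3cccc(C)c3)CC2)nc1` has not yet been measured. It differs from compound 2 in one place: 5-methylpyridin-2-yl in place of phenyl on a saturated ring carbon. Among the compounds with values here, no pair of measured compounds shows a step of this kind, so there is no measured precedent for what this change does here; the two compounds with a pyridine in the structure, compound 1 and compound 3, each gave no number at all.

Given that compound 2 already sits at a low response in this assay, the expected step of a number 4 percentage points lower from compound 2 to compound 4 (within the scatter) is small and downward, within the usual scatter, with a real chance that no number is reported at all. Compound 4 is therefore estimated to reach about 10%, somewhere between 0% and 25%.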

Compound 4, largest response reached (Emax), in percent of the reference or control that the assay uses: "not active" (no number reported)
For compound 4 the study gives words and no number, so the estimate cannot be set against anything.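

In this assay, within the data shown here, compound 2 gives 14% and compound 4 gives "not active" (no number reported) with words in place of a number, and no step between the two can be read. No measured evidence bears on this result. The compounds shown leave open whether 5-methylpyridin-2-yl in place of phenyl changes the maximal response at all.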